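Thiadiazolyl urea series: chloro to trifluoromethyl on the aryl

The compounds below may be only part of what the source reports. "The series", "measured", "known", "first", "only" and "open" are said of these compounds alone.

Measured compounds in a functional assay on PC-3 cells (Homo sapiens) for antiproliferative activity, read by MTT assay, with a stated time of 48 h; on this read-out lower numbers stand for stronger inhibition and higher numbers for weaker inhibition:
compound 1 `COc1ccc(NC(=O)Nc2nnc(Sc3ncnc4scc(-c5ccncc5)c34)s2)cc1` gives 9900 nM
compound 2 `Cc1ccc(NC(=O)Nc2nnc(Sc3ncnc4scc(-c5ccncc5)c34)s2)cc1` gives 2100 nM
compound 3 `O=C(Nc1ccc(Cl)c(Cl)c1)Nc1nnc(Sc2ncnc3scc(-c4ccncc4)c23)s1` gives 3600 nM

Compound 3 stands second highest of the three numbers; compound 2 is its nearest neighbour and compound 1 its furthest. The unmeasured compound 4 `O=C(Nc1ccc(Cl)c(C(F)(F)F)c1)Nc1nnc(Sc2ncnc3scc(-c4ccncc4)c23)s1` differs from compound 3 by trifluoromethyl in place of chloro on an aromatic carbon. Among the measured compounds shown here, the steps that bear on this all alter the aryl group on the urea nitrogen: a 4.7-fold lower number from compound 1 to compound 2 (0.67 log units; beyond the scatter) and a 2.8-fold lower number from compound 1 to compound 3 (0.44 log units; beyond the scatter) were modest, while a 1.7-fold higher number from compound 2 to compound 3 (0.23 log units; within the scatter) lay within the scatter. Exchanges between small non-polar groups on this aryl have thus moved this assay only modestly or not at all, so for compound 4 a step around a 1.2-fold lower number from compound 3 to compound 4 (0.08 log units; within the scatter) is expected, likely within the scatter. Compound 4 is therefore estimated at 3000 nM, with a range of 1200 nM to 8000 nM.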

Compound 4, half-maximal inhibitory concentration: 12100 nM
Estimate against measurement, compound 4: 4.0-fold (0.61 log units) below; measured number above the stated range.
By their numbers in this assay, from the lowest: compounds 2 and 3 (each within the scatter of the next); then compounds 1 and 4 (each within the scatter of the next).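

In this assay this position, ortho to a chloro group, proves sensitive to an exchange between small non-polar groups, with trifluoromethyl in place of chloro giving a step beyond the scatter (a 3.4-fold higher number from compound 3 to compound 4 (0.53 log units; beyond the scatter)). The same aryl also stands well apart from the 4-methylphenyl urea (a 5.8-fold higher number from compound 2 to compound 4 (0.76 log units; beyond the scatter)), yet it is not separated from the 4-methoxyphenyl urea (a 1.2-fold higher number from compound 1 to compound 4 (0.09 log units; within the scatter)). Nothing measured here bears on the reason for these steps.

Going by these compounds, how a nitrile or an amine at this position would read remains open, as does whether trifluoromethyl gives the same step without the chloro group.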